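Replacing the isopropoxycarbonyl group of compound 2

The source may hold more compounds than are shown below. What is called first, only, known or untested is meant among the compounds shown, and "the series" means these compounds.

Compound 1 `CNC(=O)c1ccc(NCc2cncn2Cc2ccc(-c3ccccc3)cc2)cc1-c1ccccc1` gives > 1000 nM as a limit
Compound 2 `CC(C)OC(=O)c1ccc(NCc2cncn2Cc2ccc(-c3ccccc3)cc2)cc1-c1ccccc1` gives > 10000 nM as a limit

In a toxicity assay on NIH3T3 cells (Mus musculus) for cytotoxicity, read by resazurin assay (a higher number here means that more compound is needed for the effect, a lower number that less compound is needed), compound 2 stands at > 10000 nM as a limit, with no number known. Compound 3 `c1ccc(-c2ccc(Cn3cncc3CNc3ccc(-c4nc5ccccc5o4)c(-c4ccccc4)c3)cc2)cc1` differs from compound 2 by 1,3-benzoxazol-2-yl in place of isopropoxycarbonyl on an aromatic carbon on the shared core. Among the measured compounds shown here, the one measured step, a step that the two limits leave unreadable from compound 1 to compound 2, has no readable size, so no step beyond the scatter is expected in this assay in either direction. The expected step is a number no higher from compound 2 to compound 3 (the limit leaves the size open) on this reading. Compound 3 is estimated at 10000 nM with an expected range of 3000 nM to 30000 nM in this measurement.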

Compound 3, half-maximal effective concentration: > 10000 nM
Compound 3 ended at the assay's limit; the forecaster's own chance of this, stated with the estimate: 65%; the middle value sits exactly at the limit.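

Among the compounds shown here, no step among compound 1, compound 2 and compound 3 can be read, as all three values are limits and not numbers. The compounds shown leave open how much of each is needed for the effect in this assay.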